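The source may report more compounds than this note shows. Statements on the series, on what has been measured and on what is new or still open speak of the compounds shown alone.

Three compounds of the series have been run in an ADME assay on L1210/0 cells (Mus musculus) for cytotoxicity, with a stated time of 48 h; on this read-out higher numbers stand for weaker inhibition and lower numbers for stronger inhibition. Compound 1 `COc1ncnc2c1ncn2C[C@@H]1C[C@H](O)c2ccccc21` returns only a limit there, > 200000 nM. Compound 3 `CC1(C)[C@@H](CO)CC[C@@]1(C)Cn1cc(I)c(=O)[nH]c1=O` likewise returns a limit, > 200000 nM. Among the measured compounds shown here, compound 2 `C=Cc1cn([C@H]2C[C@H](O)[C@@H](CO)O2)c(=O)[nH]c1=O` is the one member with an actual number in this assay, 14200 nM, and so stands apart from the limit of > 200000 nM in this assay, at which 2 of the 3 values shown sit. Compound 4 `O=c1[nH]c(=O)n([C@H]2C[C@H](O)[C@@H](CO)O2)cc1/C=C/Cl` has not yet been run in this assay; it differs from compound 2 by 2-chloroethenyl in place of vinyl on an aromatic carbon. For the measured compounds named here, no measured pair in the set carries this change, so the expectation rests on compound 2 alone. The step is expected to be modest, toward weaker inhibition if any, and probably within the scatter: a 2.1-fold higher number from compound 2 to compound 4 (0.32 log units; beyond the scatter). Compound 4 is accordingly estimated at 30000 nM, in the range 8000 nM to 150000 nM.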

Compound 4, half-maximal inhibitory concentration: > 200000 nM
Compound 4 gave a limit, no number; the forecaster's own chance of this, stated with the estimate: 25%; middle value at least 6.6-fold (0.82 log units) away from the limit.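

On this aromatic carbon, the series' first one-place change is not neutral: in this assay, 2-chloroethenyl in place of vinyl gives an at least 14-fold higher number from compound 2 to compound 4 (1.14 log units; beyond the scatter). One chlorine atom is the only difference, so the measured number of compound 2 is sensitive to the group at this position. Compound 4 gives only a limit, not a number: the limit of > 200000 nM in this assay, at which 3 of the 4 values shown sit.

On these data alone, the full size of the step remains open, as the limit gives it a floor and no ceiling. Also open, as far as these compounds go, is whether an ethyl group, a longer chain or an amine at this carbon would keep the number of compound 2.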